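Swapping bromo for methylsulfanyl on compound 3

This account rests on a few compounds, and the source may have more. Where it says the series, first, only, none or still open, it means among the compounds named here.

Of the compounds shown here, three have been measured in a functional assay on DU-145 cells (Homo sapiens) for inhibition, read by trypan blue exclusion, with a stated time of 96 h; on this read-out higher numbers stand for weaker inhibition of growth and lower numbers for stronger inhibition of growth. In this test, compound 1 `O=C(/C(=C\c1ccc(O)cc1O)Sc1ccc(Br)cc1)c1ccc(Cl)cc1` gives 50000 nM, compound 2 `COc1ccc(/C=C(/SCc2ccc(F)cc2)C(=O)c2ccc(Cl)cc2)c(OC)c1OC` gives 10000 nM and compound 3 `Cc1ccc(CS(=O)(=O)/C(=C/c2ccc(Br)cc2)C(=O)c2ccc(Cl)cc2)cc1` gives 25000 nM. Compound 3 holds the middle of these three numbers. Its gap to compound 1 lies within the usual scatter of repeated measurements, while its gap to compound 2, which has the lower number, lies beyond that scatter.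

Compound 4 `CSc1ccc(/C=C(\C(=O)c2ccc(Cl)cc2)S(=O)(=O)Cc2ccc(C)cc2)cc1` has not yet been measured in this assay. It differs from compound 3 in one place, with methylsulfanyl in place of bromo on an aromatic carbon, para to a large group: methylsulfanyl in place of bromo on an aromatic carbon. Among the compounds with values here, no two measured compounds differ in only one place, so the data give no direct reading of this change. The three measured compounds differ from one another in several places, yet compound 3 at 25000 nM stays within the scatter of compound 1 at 50000 nM. On that limited evidence, no change beyond the scatter is expected here. The expected step is a 1.3-fold lower number from compound 3 to compound 4 (0.10 log units; within the scatter), a small move towards a lower number that would stay within the scatter. For compound 4, the estimated value is 20000 nM, with an expected range of 7000 nM to 50000 nM.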

Compound 4, concentration for 50% growth inhibition: 10000 nM
Compound 4: middle estimate off by 2.0-fold (0.30 log units), on the high side; low and high end bracket the measured number.
By their numbers in this assay, from the lowest: compounds 2 and 4 (each within the scatter of the next); then compounds 3 and 1 (each within the scatter of the next).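

In this assay, replacing bromo with methylsulfanyl on an aromatic carbon, para to a large group, gives a 2.5-fold lower number from compound 3 to compound 4 (0.40 log units; beyond the scatter), a modest step. Within the data shown here, this is the first pair in the set that differs in one place, so it gives the first direct reading of a single change. It shows that this position can respond to a substituent swap: with the rest of the molecule unchanged, going from 4-bromophenyl to 4-(methylsulfanyl)phenyl strengthens growth inhibition beyond the usual scatter of the read-out. No measurement at hand gives a reason for this step.

From the compounds shown here alone, what remains open is how far this position can be taken, as a single swap gives neither a trend nor a sense of which feature of methylsulfanyl matters, and an ethylsulfanyl group, an amine or a carboxylic acid at the same place would test that. Going by these compounds, it is also open whether the same swap would give a similar step on the differently substituted frameworks of compound 1 and compound 2.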